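Chloro to methylsulfanyl on compound 3

This account rests on a few compounds, and the source may have more. Where it says the series, first, only, none or still open, it means among the compounds named here.

In a functional assay on the whole organism with Rattus norvegicus as the target (on this read-out lower numbers stand for an effect already at smaller amounts and higher numbers for an effect only at larger amounts of compound), compound 3 `Cc1cc(Cl)c(NC(=O)N(Cc2ccc(Oc3ccc(F)cc3)cc2)C2CCCCCC2)c(Cl)n1` gives > 0.1 mg/kg, a limit of the assay and not a number. Compound 1 `CSc1nc(C)nc(SC)c1NC(=O)N(Cc1ccc(Oc2ccc(F)cc2)cc1)C1CCCCCC1` gives 0.069 mg/kg, and compound 2 `COc1cc(C)nc(OC)c1NC(=O)N(Cc1ccc(Oc2ccc(F)cc2)cc1)C1CCCCCC1` gives 0.032 mg/kg. Compound 4 `CSc1cc(C)nc(Cl)c1NC(=O)N(Cc1ccc(Oc2ccc(F)cc2)cc1)C1CCCCCC1` differs from compound 3 by methylsulfanyl in place of chloro on an aromatic carbon, opposite the ring nitrogen. Within the data shown here, two measured steps bear on this: an at least 1.4-fold higher number from compound 1 to compound 3 (0.16 log units; that floor lies within the scatter) and an at least 3.1-fold higher number from compound 2 to compound 3 (0.49 log units; beyond the scatter). Each exchanges the whole substituted ring, so neither isolates this single swap. Among the measured compounds shown here, compound 1, at 0.069 mg/kg, is the only measured methylsulfanyl example. A modest move to a lower number is therefore expected, estimated as an at least 1.6-fold lower number from compound 3 to compound 4 (0.22 log units; that floor lies within the scatter). The estimate for compound 4 is 0.06 mg/kg, with an expected range of 0.025 mg/kg to 0.15 mg/kg.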

Compound 4, dose for half-maximal effect: 0.022 mg/kg
The estimate for compound 4 lay 2.7-fold (0.44 log units) above the measured number; the measured number lies below the stated range.
By their numbers in this assay, from the lowest: compounds 4 and 2 (each within the scatter of the next); then compound 1. At a limit, above all of these: compound 3.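

In this assay, methylsulfanyl in place of chloro, opposite the ring nitrogen, can now be read as a single change: an at least 4.5-fold lower number from compound 3 to compound 4 (0.65 log units; beyond the scatter), a size that is only a floor. For compound 3 the reading is a limit of the assay and not a number: the limit of > 0.1 mg/kg in this assay, at which 1 of the 4 values shown sits.

Against the other substituted rings, the readings are a 1.5-fold lower number from compound 2 to compound 4 (0.16 log units; within the scatter) and a 3.1-fold lower number from compound 1 to compound 4 (0.50 log units; beyond the scatter), so the mixed chloro and methylsulfanyl ring is separated from the first of these only within the scatter and from the second beyond it.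

As far as these compounds go, the full size of the swap stays open. So does the outcome at this position with an amine or a longer chain such as ethylsulfanyl.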